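The source may hold more compounds than are shown below. What is called first, only, known or untested is meant among the compounds shown, and "the series" means these compounds.

Measured compounds in a functional assay on A-375 cells (Homo sapiens) for cytotoxicity, read by MTT assay, with a stated time of 72 h, tested at 100 uM; a higher number here means more inhibition of growth at the concentration tested, a lower number less inhibition of growth:

- compound 1 `N/C(=N\NC(=S)N1CCCC1)c1ccc(F)cn1`: 86.6%
- compound 2 `Cc1cccc(/C(N)=N/NC(=S)N2CCSCC2)n1`: 77.4%
- compound 3 `N/C(=N\NC(=S)N1CCSCC1)c1ccccn1`: 87.8%

In this assay compound 3 gives the highest of the three numbers, though compound 1 sits within the scatter of it, so no order between the two can be read; compound 2 lies beyond the scatter below both. Within the data shown here, the one single-point step that is known is a number 10.4 percentage points higher from compound 2 to compound 3 (beyond the scatter), a modest change and one that concerns the methyl rather than the ring hydrogen replaced here.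

Compound 4 `N/C(=N\NC(=S)N1CCSCC1)c1ccc(F)cn1` differs from compound 3 by fluoro in place of hydrogen on an aromatic carbon. Among the measured compounds shown here, no measured step isolates this change. Compound 1 carries the same fluoro on its ring with a different amine and gives a number within the scatter of compound 3, which is consistent with the fluoro mattering little, but that pair differs in two places and cannot be counted as a step. The expectation is therefore a change within the scatter, a number 0.8 percentage points lower from compound 3 to compound 4 (within the scatter), with no direction claimed. Compound 4 is estimated at 87%, from 76% to 95%.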

Compound 4, percent growth inhibition at one concentration: 83.2%
Compound 4: middle estimate off by 3.8 percentage points, on the high side, and the stated range covers the measured number.
By their numbers in this assay, from the lowest: compounds 2, 4, 1 and 3 (each within the scatter of the next, the first and the last beyond it).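

In this assay, fluoro in place of hydrogen on an aromatic carbon, two atoms from the ring nitrogen and para to a large group, now has a step of its own (a number 4.6 percentage points lower from compound 3 to compound 4 (within the scatter)), and the two compounds cannot be told apart. With the fluoro kept, thiomorpholin-4-yl in place of pyrrolidin-1-yl on a thiocarbonyl carbon also stays within the scatter (a number 3.4 percentage points lower from compound 1 to compound 4 (within the scatter)). Among these compounds, neither of these changes matches the size of the methyl step (a number 10.4 percentage points higher from compound 2 to compound 3 (beyond the scatter)), the only single-place step in the set that lies beyond the scatter.

On these data alone, whether methoxy, an amine or a carboxylic acid at this same place would also leave the number within the scatter remains open. No measurement at hand accounts for any of these steps.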